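Ethyl capping of two different oxygens in one series

The compounds below may be only part of what the source reports. "The series", "measured", "known", "first", "only" and "open" are said of these compounds alone.

Of the compounds shown here, three have been tested in a functional assay on the whole organism with Rattus norvegicus as the target; on this read-out higher numbers stand for an effect only at larger amounts of compound and lower numbers for an effect already at smaller amounts. Compound 2 `CC1CCC(/C=N/c2ccccc2C(=O)O)=C2NC=C(C(=O)O)C(=O)N21` gives 1.11 umol/kg, and compound 1 `CCOC(=O)C1=CNC2=C(/C=N/c3ccccc3C(=O)O)CCC(C)N2C1=O` gives 24.8 umol/kg. Among the compounds with values here, the one change between them, (ethyl in place of hydrogen on an oxygen next to a carbonyl group), produced a 22-fold higher number from compound 2 to compound 1 (1.35 log units; beyond the scatter). Compound 3 `CC1CCC(/C=N/c2ccc(O)cc2)=C2NC=C(C(=O)O)C(=O)N21` gives 1.2 umol/kg, a value within the scatter of compound 2; the difference between the two cores of compound 2 and compound 3 is not broken down here.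

Compound 4 `CCOc1ccc(/N=C/C2=C3NC=C(C(=O)O)C(=O)N3C(C)CC2)cc1` is not yet measured. It differs from compound 3 by ethyl in place of hydrogen on an oxygen on an aromatic ring. This is the same kind of change as that from compound 2 to compound 1, but not the same: there the oxygen sat next to a carbonyl group with a carbonyl carbon as its other neighbour, whereas here the oxygen sits on an aromatic ring with an aromatic carbon as its other neighbour. The large earlier step rested on capping an oxygen next to a carbonyl group, and that group is untouched in compound 4. A smaller step is therefore expected, a 2.5-fold higher number from compound 3 to compound 4 (0.40 log units; beyond the scatter), because the earlier 22-fold higher number from compound 2 to compound 1 (1.35 log units; beyond the scatter) arose at a different place. For compound 4 in this assay an estimated 3 umol/kg is expected, between 1.2 umol/kg and 10 umol/kg.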

Compound 4, dose for 50% inhibition: 8.96 umol/kg
Estimate against measurement, compound 4: 3.0-fold (0.48 log units) below; the measured number falls inside the stated range.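

In this assay, ethyl in place of hydrogen on an oxygen on an aromatic ring gives a 7.5-fold higher number from compound 3 to compound 4 (0.87 log units; beyond the scatter), so capping an oxygen with ethyl raises the number in both pairs shown. The size of the step, however, does not carry over from one core to the other: the same change on two cores in this assay, a 22-fold higher number (1.35 log units; beyond the scatter) from compound 2 to compound 1 and a 7.5-fold higher number (0.87 log units; beyond the scatter) from compound 3 to compound 4, 3.0-fold (0.48 log units) apart, beyond the scatter of two such steps The capped oxygen differs along with the core in these two pairs, so they do not tell which of the two sets the gap, and they give no reason for either step.

On these data alone, it remains open whether a methyl or a longer chain such as propyl on the oxygen on an aromatic ring would give a step of similar size, and how an amine in place of the hydroxy would read. Also open, as far as these compounds go, is whether capping both oxygens with ethyl in a single compound would add the two steps together.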